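Bromo for Hydrogen: What to Expect of Compound 4

The source may report more compounds than this note shows. Statements on the series, on what has been measured and on what is new or still open speak of the compounds shown alone.

Compound 1 `CCN(CC)CN1C(=O)/C(=N\c2nc3ccc(C)cc3s2)c2ccccc21` gives 27500 nM in an ADME assay on 184B5 cells (Homo sapiens) for cytotoxicity, read by sulforhodamine B assay, with a stated time of 48 h; a higher number here means a weaker inhibitor of growth, a lower number a stronger inhibitor of growth.
Compound 2 `O=C1C(=O)N(CN(c2ccccc2)c2ccccc2)c2cccc(Cl)c21` gives 96800 nM.
Compound 3 `O=C1C(=O)N(CN(c2ccccc2)c2ccccc2)c2ccccc21` gives 33700 nM.

Compound 3 stands second highest of the three numbers; its nearest neighbour is compound 1, within the scatter, while compound 2 lies beyond it. Compound 4 `O=C1C(=O)N(CN(c2ccccc2)c2ccccc2)c2cccc(Br)c21` differs from compound 3 by bromo in place of hydrogen on an aromatic carbon. Within the data shown here, one measured step bears on this change: a 2.9-fold lower number from compound 2 to compound 3 (0.46 log units; beyond the scatter), where a chloro on an aromatic carbon was replaced by hydrogen. The entry of a bromo in compound 4 is the reverse kind of change, so a step of comparable size in the opposite direction, toward a weaker inhibitor of growth, is expected, about a 2.4-fold higher number from compound 3 to compound 4 (0.38 log units; beyond the scatter). Compound 4 is therefore estimated at 80000 nM, with a range from 35000 nM to 200000 nM.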

Compound 4, concentration for 50% growth inhibition: 98500 nM
Compound 4: middle estimate off by 1.2-fold (0.09 log units), on the low side; low and high end bracket the measured number.
By their numbers in this assay, from the lowest: compounds 1 and 3 (each within the scatter of the next); then compounds 2 and 4 (each within the scatter of the next).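

Bromo in place of hydrogen on this aromatic carbon gives a 2.9-fold higher number from compound 3 to compound 4 (0.47 log units; beyond the scatter), so a second halogen at this position now stands apart from hydrogen, as chloro did in compound 2. Bromo in place of chloro gives a 1.0-fold higher number from compound 2 to compound 4 (0.01 log units; within the scatter), so this assay does not tell these two halogens apart here. No measurement at hand speaks to what lies behind these steps.

The compounds shown leave open whether fluoro, or a group that is not a halogen, such as an amine or a methoxy group, would move the number at this aromatic carbon. They also leave open whether the bromo step would hold on the core of compound 1.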